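The compounds below may be only part of what the source reports. "The series", "measured", "known", "first", "only" and "open" are said of these compounds alone.

Measured in a functional assay on the whole organism with Scenedesmus acutus as the target; a lower number here means a stronger inhibitor, a higher number a weaker inhibitor:
- compound 1 `O=C1C2=C(CCCC2)C(=O)N1c1ccc(Cl)cc1F`: 24.6 nM
- compound 2 `COC(=O)c1cc(N2C(=O)C3=C(CCCC3)C2=O)c(F)cc1Cl`: 110 nM

Compound 2 holds the higher of the two numbers, which makes it the weaker inhibitor of the pair. Compound 3 `CCCOC(=O)c1cc(N2C(=O)C3=C(CCCC3)C2=O)c(F)cc1Cl` lengthens its ester: ethyl in place of hydrogen on a saturated chain carbon bound to an oxygen next to a carbonyl group, with ethyl in place of hydrogen on a saturated chain carbon bound to an oxygen next to a carbonyl group. Among the compounds with values here, the only measured step that bears on this is a 4.5-fold higher number from compound 1 to compound 2 (0.65 log units; beyond the scatter), where the methoxycarbonyl group itself replaces hydrogen. Within the data shown here, no measured pair varies the ester chain, so this modest step is only a loose guide. In this assay, a change no larger than that step is expected, most likely within the scatter and with no firm direction. The expected change is a 1.4-fold lower number from compound 2 to compound 3 (0.14 log units; within the scatter). For compound 3 the estimate is 80 nM, with an expected range of 25 nM to 250 nM.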

Compound 3, half-maximal inhibitory concentration: 89.1 nM
Estimate against measurement, compound 3: 1.1-fold (0.05 log units) below; low and high end bracket the measured number.
By their numbers in this assay, from the lowest: compound 1; then compounds 3 and 2 (each within the scatter of the next).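

Lengthening the ester from methoxycarbonyl to propoxycarbonyl gives, in this assay, a 1.2-fold lower number from compound 2 to compound 3 (0.09 log units; within the scatter) and so has no readable effect at this saturated chain carbon bound to an oxygen next to a carbonyl group. The gap to the compound without an ester persists with the longer chain, with a 3.6-fold higher number from compound 1 to compound 3 (0.56 log units; beyond the scatter) alongside a 4.5-fold higher number from compound 1 to compound 2 (0.65 log units; beyond the scatter), so both esters in this assay stand apart from compound 1 by a step beyond the scatter. Nothing available explains why these two ester chains read alike.

Still open, going by these compounds, is whether a longer chain, a branched isopropyl ester or a benzyl ester would stay at this level. Also open, on these data alone, is how a free carboxylic acid or a primary amide in place of the ester would read in this assay and whether either would close the gap to compound 1.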